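A few compounds are considered here, and "the series" means these few. Any claim that something is new, unique, unknown or untested is made for them only; others in the source may bear on it.

Measured in an ADME assay on MDCK cells (Canis lupus familiaris) for permeability, in the apical to basolateral direction; a higher number here means that the compound crosses the layer faster, a lower number that the compound crosses the layer more slowly:
- compound 1 `CC(C)[C@H](C[C@H]1OC(=O)NC1=O)c1ccc(-c2ccc3cccc(F)c3c2)[nH]c1=O`: 10.3 10^-6 cm/s
- compound 2 `CC(C)/C(=C1\C(=O)NC(=O)N1C)c1ccc(-c2ccc3cccc(F)c3c2)[nH]c1=O`: 6.85 10^-6 cm/s

On these numbers, compound 1 stands within the usual scatter of compound 2, so the two cannot be told apart. Compound 3 `CC(C)[C@H](C[C@H]1SC(=O)NC1=O)c1ccc(-c2ccc3cccc(F)c3c2)[nH]c1=O` differs from compound 1 at one place, with 2,4-dioxo-1,3-thiazolidin-5-yl in place of 2,4-dioxo-1,3-oxazolidin-5-yl on a saturated chain carbon, two bonds along the chain from an aromatic carbon. Among the measured compounds shown here, no measured pair shows this exchange, so no step beyond the scatter is expected in this assay. The expected change is small: a 1.1-fold higher number from compound 1 to compound 3 (0.05 log units; within the scatter). The estimate for compound 3 is 11.5 10^-6 cm/s, with an expected range of 6 10^-6 cm/s to 21 10^-6 cm/s.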

Compound 3, apparent permeability: 17.6 10^-6 cm/s
For compound 3 the middle estimate is 1.5-fold (0.18 log units) below the measured one; low and high end bracket the measured number.
By their numbers in this assay, from the lowest: compounds 2, 1 and 3 (each within the scatter of the next, the first and the last beyond it).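

Among the compounds shown here, the first pair that differs only at this position shows, in this assay, that 2,4-dioxo-1,3-thiazolidin-5-yl in place of 2,4-dioxo-1,3-oxazolidin-5-yl gives a 1.7-fold higher number from compound 1 to compound 3 (0.23 log units; within the scatter) and so leaves compound 1 and compound 3 indistinguishable. At this saturated chain carbon, then, replacing the ring oxygen with sulfur makes no readable difference in this pair. Nothing available explains this result.

Still open, from the compounds shown here alone, is whether a very different group at this place, such as a carboxylic acid or an amine, would produce a step beyond the scatter.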